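Swapping Methyl for Fluoro on the Pendant Ring

This account rests on a few compounds, and the source may have more. Where it says the series, first, only, none or still open, it means among the compounds named here.

Of the compounds shown here, three built on one shared core have been tested in an assay on CHO cells for displacement of a labelled ligand from adenosine receptor A3 (Homo sapiens), read by scintillation counting, with a stated time of 120 min; on this read-out lower numbers stand for stronger inhibition and higher numbers for weaker inhibition. Compound 1 `Cc1ccc(-c2nc3c(=O)[nH]c(C)nc3s2)cc1` gives 33 nM in this assay. Among the measured compounds shown here, compound 2 `Cc1nc2sc(-c3ccc(F)cc3)nc2c(=O)[nH]1` gives 107 nM, and the change a 3.2-fold higher number from compound 1 to compound 2 (0.51 log units; beyond the scatter) is the only step between measured compounds that differ in a single place. Compound 3 `Cc1cccc(-c2nc3c(=O)[nH]c(C)nc3s2)c1` gives 384 nM in this assay, the highest of the three numbers, lying beyond the scatter from compound 2 and further still from compound 1.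

Compound 4 `Cc1nc2sc(-c3cccc(F)c3)nc2c(=O)[nH]1` differs from compound 3 by fluoro in place of methyl on an aromatic carbon. For the measured compounds named here, the one measured step that bears on this is the same swap made at another position on that ring, from compound 1 to compound 2, which was modest and raised the number beyond the scatter. Compound 4 is therefore expected to show a rise of similar size, a 2.1-fold higher number from compound 3 to compound 4 (0.32 log units; beyond the scatter), in this assay. Compound 4 is estimated at 800 nM, with a range from 250 nM to 2500 nM.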

Compound 4, inhibition constant: 109 nM
The estimate for compound 4 lay 7.3-fold (0.87 log units) above the measured number; measured number outside the range, below it.
By their numbers in this assay, from the lowest: compound 1; then compounds 2 and 4 (each within the scatter of the next); then compound 3.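

In this assay, fluoro in place of methyl meta to a large group gives a 3.5-fold lower number from compound 3 to compound 4 (0.55 log units; beyond the scatter), so here the swap lowers the number, whereas on compound 1 it raised it. Fluoro therefore does not simply give a weaker or a stronger result than methyl on this ring: with methyl the better of the pair in compounds 1 and 2, and fluoro the better in compounds 3 and 4, neither group is preferred at both places. A step measured at one place on the ring thus cannot be carried over to another, as the two steps show when set side by side: the same change on two cores in this assay, a 3.2-fold higher number (0.51 log units; beyond the scatter) from compound 1 to compound 2 and a 3.5-fold lower number (0.55 log units; beyond the scatter) from compound 3 to compound 4, 11-fold (1.06 log units) apart, beyond the scatter of two such steps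

The compounds shown do not tell why the direction reverses. They also leave open how a chloro, a methoxy or an amine at this position would compare with methyl and fluoro.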